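Swapping cyclohexyl for propyl on the amide nitrogen

The source may hold more compounds than are shown below. What is called first, only, known or untested is meant among the compounds shown, and "the series" means these compounds.

Going by the values given here, compound 2 `C=CC1=C(C(=O)NC2CCCCC2)C(c2ccc(OC)c(OC)c2)OC1` is the only compound of the three measured here that gives an actual number in a functional assay on QGY7701 cells (Homo sapiens) for cytotoxicity, read by MTT assay, with a stated time of 24 h; on this read-out lower numbers stand for stronger inhibition and higher numbers for weaker inhibition: compound 2 gives 7490 nM. Compound 1 `C=CC1=C(C(=O)NCc2ccccc2)C(c2ccc(OC)c(OC)c2)OC1` carries benzyl instead of cyclohexyl on the amide-type nitrogen, and in this assay compound 1 reaches only the limit of > 100000 nM. Compound 3 `C=CC1=C(C(=O)NC2CCCCC2)C(c2ccc(OC)cc2)OC1` keeps the cyclohexyl but lacks one methoxy on the aromatic ring, and in this assay compound 3 also gives only the limit of > 100000 nM. Put together, (the limit of > 100000 nM in this assay, at which 2 of the 3 values shown sit). Both measured steps are large: an at least 13-fold lower number from compound 1 to compound 2 (1.12 log units; beyond the scatter), and an at least 13-fold higher number from compound 2 to compound 3 (1.12 log units; beyond the scatter).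

Compound 4 `C=CC1=C(C(=O)NCCC)C(c2ccc(OC)c(OC)c2)OC1` has not yet been measured. It differs from compound 2 by propyl in place of cyclohexyl on an amide-type nitrogen. Among the compounds with values here, of the measured steps, only the step from compound 1 to compound 2 concerns the group on this nitrogen; it shows that changing that group can move the number beyond the limit. Propyl is neither benzyl nor cyclohexyl, so no measured step fixes the direction, but a large move is plausible, and a weaker result with a real chance of another limit seems more likely than a gain. Compound 4 is therefore expected to give about 30000 nM, within 7000 nM to 130000 nM, in this assay. The expected step is a 4.0-fold higher number from compound 2 to compound 4 (0.60 log units; beyond the scatter).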

Compound 4, half-maximal inhibitory concentration: > 100000 nM
Compound 4 ended at the assay's limit; the forecaster's own chance of this, stated with the estimate: 40%; middle value at least 3.3-fold (0.52 log units) from the limit.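

In this assay, putting propyl in place of cyclohexyl on the amide-type nitrogen gives an at least 13-fold higher number from compound 2 to compound 4 (1.12 log units; beyond the scatter). For compound 4, > 100000 nM is a limit of the assay and not a number, and as compound 1 also sits at a limit, the step between those two cannot be read. Of the three groups shown on this nitrogen, benzyl and propyl both end at the limit and only cyclohexyl gives a real number, so a second replacement of cyclohexyl now points the same way, although compound 3 goes against any simple rule by keeping cyclohexyl and still sitting at the limit: the limit of > 100000 nM in this assay, at which 3 of the 4 values shown sit.

Open, going by these compounds, is whether a smaller ring such as cyclopentyl, a larger ring such as cycloheptyl, or a longer chain such as hexyl on this nitrogen would keep a real number. Going by these compounds alone, also open is whether any group here, including a chain ending in an amine or a carboxylic acid, could bring the number lower than the one for compound 2, 7490 nM.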